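The source may report more compounds than this note shows. Statements on the series, on what has been measured and on what is new or still open speak of the compounds shown alone.

Compound 1 `Cc1c(Cc2ccccc2)c(=O)oc2cc(OCC(O)CNc3ccccc3)ccc12` gives in an ADME assay on A549 cells (Homo sapiens) for cytotoxicity, read by CellTiter-Glo (on this read-out lower numbers stand for higher toxicity in this test and higher numbers for lower toxicity in this test), a limit, > 100000 nM.
Compound 2 `Cc1c(Cc2ccccc2)c(=O)oc2cc(OCC(O)CNc3ccc(Br)cc3)ccc12` gives in this assay a limit, > 100000 nM.

Both values shown are limits of the assay, so the step that the two limits leave unreadable from compound 1 to compound 2 cannot be read; see (the limit of > 100000 nM in this assay, at which 2 of the 2 values shown sit). Compound 2 therefore stands only at the limit. Compound 3 `Cc1c(Cc2ccccc2)c(=O)oc2cc(OCC(O)CNCc3ccccc3)ccc12` differs from compound 2 by benzyl in place of 4-bromophenyl on an amine nitrogen. Within the data shown here, no measured step bears on this change, and neither measured compound shows toxicity within the tested range. Compound 3 is expected to stay at the limit as well, with an expected step of a number no higher from compound 2 to compound 3 (the limit leaves the size open) amounting to none beyond the scatter. The estimate for compound 3 is 100000 nM, in the range 40000 nM to 250000 nM.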

Compound 3, half-maximal cytotoxic concentration: > 100000 nM
Compound 3 gave a limit, no number; the forecaster's own chance of this, stated with the estimate: 80%; the middle value lies on the limit itself.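

No step can be read among compound 1, compound 2 and compound 3 in this assay, as each gives only a limit: the limit of > 100000 nM in this assay, at which 3 of the 3 values shown sit. From the compounds shown here alone, whether the bromo or benzyl changes affect toxicity in this test remains open.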